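Diaryl urea series: aryl exchange from compound 1 to compound 4

The compounds below may be only part of what the source reports. "The series", "measured", "known", "first", "only" and "open" are said of these compounds alone.

Compound 1 `COc1cc(Br)ccc1Nc1cc(NC(=O)Nc2c(Cl)cccc2Cl)ncn1`: 43%
Compound 2 `CCc1cccc(Nc2cc(NC(=O)Nc3cc(OC)cc(OC)c3)ncn2)c1`: 36.7%
Compound 3 `COc1cc(NC(=O)Nc2cc(Nc3cc(C)cc(F)c3)ncn2)cc(OC)c1`: 35.3%

In a functional assay on NCI-H226 cells (Homo sapiens) for inhibition, read by MTT assay, with a stated time of 48 h, tested at 10 uM (a higher number here means more inhibition at the concentration tested (going by the name of the read-out), a lower number less inhibition), compound 1 gives the highest of the three numbers, yet both compound 2 and compound 3 lie within the scatter of it, so no order among the three can be read. Compound 4 `Cc1ccc(Nc2cc(NC(=O)Nc3c(Cl)cccc3Cl)ncn2)cc1C` differs from compound 1 by 3,4-dimethylphenyl in place of 4-bromo-2-methoxyphenyl on a nitrogen on an aromatic ring. Going by the values given here, one measured step concerns an aryl exchange on that same nitrogen: a number 1.4 percentage points lower from compound 2 to compound 3 (within the scatter). That step stayed within the scatter, and nothing else among the measured compounds speaks to the change, so no movement beyond the scatter is expected from compound 1 to compound 4; the estimated step is a number 3 percentage points lower from compound 1 to compound 4 (within the scatter). Compound 4 is therefore expected to give 40%, with a range from 26% to 54%.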

Compound 4, a percentage reported as inhibition, at one concentration (the size of the read-out at that concentration, not a potency): 41.3%
The estimate for compound 4 lay 1.3 percentage points below the measured number; measured number inside the range.
By their numbers in this assay, from the lowest: compounds 3, 2, 4 and 1 (each within the scatter of the next).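

In this assay, 3,4-dimethylphenyl in place of 4-bromo-2-methoxyphenyl on the nitrogen gives a number 1.7 percentage points lower from compound 1 to compound 4 (within the scatter) and stays within the scatter. The earlier aryl exchange at this position belonged to the compound 2 pair, whereas this step shows the same outcome on the core of compound 1, with bromine and the hydrogen-bond acceptor of the methoxy group both gone from the aryl group. No measured evidence accounts for this flat result.

The compounds shown leave open what a carboxylic acid or a dimethylamino group on this aryl ring would do. They also leave open whether a saturated ring such as cyclohexyl could take the place of the aryl group on this nitrogen.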